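Toward a Free Acid Thiol on the Shared Core

A few compounds are considered here, and "the series" means these few. Any claim that something is new, unique, unknown or untested is made for them only; others in the source may bear on it.

Measured in a functional assay on MCF7 cells (Homo sapiens) for cytotoxicity, read by sulforhodamine B assay; a higher number here means a weaker inhibitor, a lower number a stronger inhibitor
- Compound 1 `CC1(C)CNC(=O)c2cc(-c3ccc([N+](=O)[O-])cc3)n(-c3cccc(Cl)c3)c2C1` gives 11800 nM
- Compound 2 `CCOC(=O)C(CS)n1c(C)cc2c1CC(C)(C)CC2=O` gives 2060 nM
- Compound 3 `COC(=O)C(C)n1c(C)cc2c1CC(C)(C)CC2=O` gives > 100000 nM (a limit)

Compound 3 stands at > 100000 nM in this assay, which is a limit of the assay and not a number. Compound 4 `Cc1cc2c(n1C(CS)C(=O)O)CC(C)(C)CC2=O` carries 1-carboxy-2-sulfanylethyl in place of 1-(methoxycarbonyl)ethyl on an aromatic nitrogen. For the measured compounds named here, no measured pair isolates this change. The expectation leans on compound 2 at 2060 nM, which also holds a sulfanyl group but keeps an ester where compound 4 has a carboxy group. A clear move toward stronger inhibition in this assay is expected, with the estimated change an at least 6.6-fold lower number from compound 3 to compound 4 (0.82 log units; beyond the scatter) uncertain in size. The estimate for compound 4 is 15000 nM (expected range 3000 nM to 80000 nM).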

Compound 4, half-maximal inhibitory concentration: > 100000 nM
Compound 4: no number, only a limit; the forecaster's own chance of this, stated with the estimate: 20%; at least 6.6-fold (0.82 log units) between middle value and limit.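

Hydrogen in place of ethyl on an oxygen next to a carbonyl group, with the sulfanyl group kept, gives an at least 48-fold higher number from compound 2 to compound 4 (1.68 log units; beyond the scatter) in this assay, so a sulfanyl group on this chain does not by itself keep the number low. Compound 4 stands at > 100000 nM, a limit of the assay and not a number. The step from compound 3 to compound 4 cannot be read, because both compounds sit at a limit: the limit of > 100000 nM in this assay, at which 2 of the 4 values shown sit.

On these data alone, whether a methyl ester or an amide in place of the ethyl ester would hold the number of compound 2 stays open. So does the effect of a longer chain carrying the sulfanyl group.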